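The source may report more compounds than this note shows. Statements on the series, on what has been measured and on what is new or still open speak of the compounds shown alone.

Compound 1 `O=C(CCCCCn1cc(Nc2ncc3ccn(Cc4ccccc4)c3n2)cn1)NO` is a hydroxamic acid whose chain carries a pyrazole linked to the shared core. Among the measured compounds shown here, in an assay on isolated protein for inhibition of protein deacetylase HDAC6 (Homo sapiens), with a stated time of 60 min (on this read-out higher numbers stand for weaker inhibition and lower numbers for stronger inhibition), compound 1 gives 13.8 nM, the second highest of the three numbers measured so far. Its nearest neighbour is compound 2 `O=C(CCCCCCn1cc(Nc2ncc3ccn(Cc4ccccc4)c3n2)cn1)NO`, which gives 12.5 nM; the step of a 1.1-fold lower number from compound 1 to compound 2 (0.04 log units; within the scatter) shows that the longer chain changes nothing of note. Compound 3 `O=C(CCCCCCn1cc(Nc2ncc3ccn(Cc4ccccc4Cl)c3n2)cn1)NO` gives 41.5 nM, a higher number than compound 1 that lies beyond the scatter.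

Compound 4 `O=C(CCCCCn1cc(Nc2ncc3ccn(Cc4cccc(F)c4)c3n2)cn1)NO` differs from compound 1 by fluoro in place of hydrogen on an aromatic carbon. For the measured compounds named here, the one measured step that bears on it is a 3.3-fold higher number from compound 2 to compound 3 (0.52 log units; beyond the scatter), where a halogen entered the same benzyl ring and the number rose modestly. Fluoro is not chloro and enters at a different place on that ring, so the analogy is loose; the step from compound 2 to compound 3 sets a ceiling rather than a forecast.

For compound 4 a small rise or no change beyond the scatter is therefore expected, amounting to a 1.3-fold higher number from compound 1 to compound 4 (0.12 log units; within the scatter). Compound 4 is estimated at 18 nM in this assay, with a range from 8 nM to 45 nM.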

Compound 4, half-maximal inhibitory concentration: 13.7 nM
For compound 4 the middle estimate is 1.3-fold (0.12 log units) above the measured one, within the range that was stated.
By their numbers in this assay, from the lowest: compounds 2, 4 and 1 (each within the scatter of the next); then compound 3.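

In this assay, the change from benzyl to 3-fluorobenzyl gives a 1.0-fold lower number from compound 1 to compound 4 (0.00 log units; within the scatter), so fluoro on an aromatic carbon, meta to a large group, leaves the number of compound 1 where it was. Until now the only halogen on this ring was the chloro of a 3.3-fold higher number from compound 2 to compound 3 (0.52 log units; beyond the scatter), a step beyond the scatter, so the benzyl ring now shows one halogen change that moves the number and one that does not. The two changes differ in the halogen, in its place on the ring and in the chain that carries them, and no measurement shown here accounts for the result.

The compounds shown leave open whether 3-chlorobenzyl would read like 3-fluorobenzyl or like the chloro compound 3, and whether 3-fluorobenzyl would behave the same way on the longer chain of compound 2. Also open, as far as these compounds go, is how a larger group at this place on the ring, such as methoxy, trifluoromethyl or an amine, would read in this assay.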